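Trimming a Cyclohexyl Ether on a Shared Core

A few compounds are considered here, and "the series" means these few. Any claim that something is new, unique, unknown or untested is made for them only; others in the source may bear on it.

Compound 1, `[O-][n+]1nc(NCOC2CCCCC2)[n+]([O-])c2ccccc21`: 1200 nM
Compound 2, `O=[N+]([O-])c1cccc(COCNc2n[n+]([O-])c3ccccc3[n+]2[O-])c1`: 3440 nM
Compound 3, `[O-][n+]1nc(NCOCc2ccc(C(F)(F)F)cc2)[n+]([O-])c2ccccc21`: 4270 nM

Of the compounds shown here, three sharing one core have been tested in a functional assay on A549 cells (Homo sapiens) for cytotoxicity, read by MTT assay, with a stated time of 72 h; on this read-out lower numbers stand for stronger inhibition and higher numbers for weaker inhibition. Compound 1 gives the lowest number of the three; compound 2 and compound 3 both lie beyond the scatter from it, so compound 1 is the strongest inhibitor among those measured. Compound 4, `CCCOCNc1n[n+]([O-])c2ccccc2[n+]1[O-]`, has not yet been tested. It differs from compound 1 in a single place: propyl in place of cyclohexyl on an oxygen on a saturated carbon. Within the data shown here, no measured pair shows what this kind of change does, so the expectation rests on the structural change alone. A modest weakening is expected, a 2.1-fold higher number from compound 1 to compound 4 (0.32 log units; beyond the scatter), though it could well fall inside the scatter. Compound 4 is expected to give about 2500 nM, with a likely range from 800 nM to 8000 nM.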

Compound 4, half-maximal inhibitory concentration: 3740 nM
Compound 4: the middle estimate sits 1.5-fold (0.17 log units) below what was measured; the measured number falls inside the stated range.
By their numbers in this assay, from the lowest: compound 1; then compounds 2, 4 and 3 (each within the scatter of the next).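

In this assay, among these compounds, the move from cyclohexyl to propyl on the ether oxygen gives a 3.1-fold higher number from compound 1 to compound 4 (0.49 log units; beyond the scatter) and is the first one-place comparison at this position. It shows that the group on this oxygen matters, with cyclohexyl giving the stronger inhibition of the two. Nothing measured here explains why this step occurs.

Going by these compounds, whether the ring itself or simply the larger carbon group counts remains open. A hexyl chain or a cyclopentyl ring on the same oxygen would help separate those two readings.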